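Notes on the ketone aryl group: compound 3 to compound 4

This account rests on a few compounds, and the source may have more. Where it says the series, first, only, none or still open, it means among the compounds named here.

Three measured compounds share one core and differ only in the aryl group on the carbonyl carbon. Compound 1 `COc1cc(-c2cc(/C=C/C(=O)c3ccc(N)cc3)[nH]n2)cc(OC)c1OC` gives 2010 nM in a functional assay on HCC 2998 cells (Homo sapiens) for inhibition, read by sulforhodamine B assay, with a stated time of 48 h; a higher number here means a weaker inhibitor of growth, a lower number a stronger inhibitor of growth. Compound 2 `COc1ccc(C(=O)/C=C/c2cc(-c3cc(OC)c(OC)c(OC)c3)n[nH]2)cc1OC` gives 2130 nM in this assay, and compound 3 `COc1ccc(C(=O)/C=C/c2cc(-c3cc(OC)c(OC)c(OC)c3)n[nH]2)cc1` gives 1780 nM in this assay. Compound 3 stands at the lowest of the three numbers, but its separations from the other two, a 1.1-fold lower number from compound 1 to compound 3 (0.05 log units; within the scatter) and a 1.2-fold lower number from compound 2 to compound 3 (0.08 log units; within the scatter), are within the scatter, as is a 1.1-fold higher number from compound 1 to compound 2 (0.03 log units; within the scatter); no ordering among the three is supported by these numbers.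

Compound 4 `COc1cc(-c2cc(/C=C/C(=O)c3ccc(F)c(F)c3)[nH]n2)cc(OC)c1OC` is not yet measured. It differs from compound 3 by 3,4-difluorophenyl in place of 4-methoxyphenyl on a carbonyl carbon. The three measured steps all exchange this same aryl group, and none of them moved the number beyond the scatter. Among the measured compounds shown here, no measured compound here carries a fluorine-bearing group, so the expectation rests on those flat steps alone. Compound 4 is expected to give about 2000 nM in this assay, within 700 nM to 6000 nM. The estimated step of a 1.1-fold higher number from compound 3 to compound 4 (0.05 log units; within the scatter) is expected to stay within the scatter.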

Compound 4, concentration for 50% growth inhibition: 3690 nM
The estimate for compound 4 lay 1.8-fold (0.27 log units) below the measured number; measured number inside the range.
By their numbers in this assay, from the lowest: compounds 3, 1, 2 and 4 (each within the scatter of the next, the first and the last beyond it).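

In this assay, the aryl group on the carbonyl carbon now gives one step beyond the scatter, a modest one (a 2.1-fold higher number from compound 3 to compound 4 (0.32 log units; beyond the scatter)), so this position is not flat across every exchange. The same 3,4-difluorophenyl group stays within the scatter against the other two aryl groups (a 1.7-fold higher number from compound 2 to compound 4 (0.24 log units; within the scatter)) and (a 1.8-fold higher number from compound 1 to compound 4 (0.26 log units; within the scatter)), so compound 4 separates from compound 3 alone and no general effect of the difluoro exchange is supported. Nothing available bears on why this single step exceeds the scatter.

Open, on these data alone, is whether one fluorine on the phenyl ring would give the same result as the two in compound 4. Also open, as far as these compounds go, is how a chlorine, a trifluoromethyl or a nitrile on that ring would compare.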